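The compounds below may be only part of what the source reports. "The series", "measured", "known", "first", "only" and "open" are said of these compounds alone.

Within the data shown here, compound 2 `CCCCCCc1c(F)c(N)c2c(=O)cc(-c3ccc(N)c(F)c3)oc2c1F` is the one member of this pair with a measured number: in a functional assay on HeLa cells (Homo sapiens) for cytotoxicity, read by neutral red uptake, with a stated time of 3 days (a lower number here means a stronger inhibitor, a higher number a weaker inhibitor), compound 2 gives 21000 nM. Compound 1 `CCc1c(F)c(N)c2c(=O)cc(-c3ccc(N)c(F)c3)oc2c1F` carries ethyl where compound 2 carries hexyl. In this assay, among the measured compounds shown here, compound 1 gives only a limit, > 100000 nM, and it is the one compound sitting at that limit (the limit of > 100000 nM in this assay, at which 1 of the 2 values shown sits). For the measured compounds named here, the single measured step runs an at least 4.7-fold lower number from compound 1 to compound 2 (0.67 log units; beyond the scatter), so lengthening the chain at that position gave a lower number in this assay.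

Compound 3 `Nc1ccc(-c2cc(=O)c3c(N)c(F)c(Br)c(F)c3o2)cc1F` takes the change (bromo in place of hexyl on an aromatic carbon). This undoes the chain growth that separated compound 1 from compound 2 and replaces the whole chain with a single heavy atom, a substituent closer in size to the ethyl of compound 1 than to the hexyl of compound 2. Going by the values given here, since the only measured step, from the shorter to the longer chain, lowered the number in this assay, the removal of the chain is expected to raise it again, with a fair chance that the assay returns only a limit. The step is expected to be a 3.3-fold higher number from compound 2 to compound 3 (0.52 log units; beyond the scatter). Compound 3 is thus estimated at 70000 nM in this assay, within the range 25000 nM to 200000 nM.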

Compound 3, half-maximal inhibitory concentration: > 100000 nM
Compound 3 was reported as a limit; the forecaster's own chance of this, stated with the estimate: 40%; middle value at least 1.4-fold (0.15 log units) from the limit.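

Replacing hexyl with bromo at this position gives an at least 4.7-fold higher number from compound 2 to compound 3 (0.67 log units; beyond the scatter) in this assay, so a change that removes the chain moves the number the opposite way from the step that lengthened ethyl to hexyl. As far as these compounds go, compound 3 is reported only as a limit, > 100000 nM, so the number it would otherwise have is unknown and the size of this step has only a lower bound. The step between the ethyl and bromo compounds cannot be read, and those two substituents cannot be ordered against each other, because both compounds stand at the same limit: the limit of > 100000 nM in this assay, at which 2 of the 3 values shown sit.

With hexyl the only substituent here that gives a measured number, the compounds shown cannot tell whether chain length itself goes with the lower number or whether some other feature of hexyl does. Open too, from the compounds shown here alone, is how the number would respond at this position to butyl, to a longer chain such as octyl, or to a different kind of group such as phenyl, an amine or a carboxylic acid.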